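Tuning the ether-linked saturated ring on a sulfonamide series

The source may hold more compounds than are shown below. What is called first, only, known or untested is meant among the compounds shown, and "the series" means these compounds.

Measured compounds in an assay on isolated protein for displacement of a labelled ligand from Apoptosis regulator Bcl-2 (Homo sapiens), with a stated time of 15 min; a lower number here means a stronger inhibitor, a higher number a weaker inhibitor:
compound 1 `CN1CCC(CNc2ccc(S(=O)(=O)NC(=O)c3ccc(N4CCN(CC5=C(c6ccc(C(F)(F)F)cc6)CC(C)(C)CC5)CC4)cc3Oc3cnc4[nH]ccc4c3)cc2[N+](=O)[O-])C1`, 2.4 nM
compound 2 `CC1(C)CCC(CN2CCN(c3ccc(C(=O)NS(=O)(=O)c4ccc(NC5CCOC5)c([N+](=O)[O-])c4)c(Oc4cnc5[nH]ccc5c4)c3)CC2)=C(c2ccc(C(F)(F)F)cc2)C1`, 1.9 nM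
compound 3 `CC1(C)CCC(CN2CCN(c3ccc(C(=O)NS(=O)(=O)c4ccc(OCC5CCOC5)c([N+](=O)[O-])c4)c(Oc4cnc5[nH]ccc5c4)c3)CC2)=C(c2ccc(C(F)(F)F)cc2)C1`, 4.4 nM

Compound 3 gives the highest number of the three; its gap to compound 1 is within the scatter, while a 2.3-fold higher number from compound 2 to compound 3 (0.36 log units; beyond the scatter) is a modest step beyond it. Compound 4 `CC(Oc1ccc(S(=O)(=O)NC(=O)c2ccc(N3CCN(CC4=C(c5ccc(C(F)(F)F)cc5)CC(C)(C)CC4)CC3)cc2Oc2cnc3[nH]ccc3c2)cc1[N+](=O)[O-])C1CCOCC1` differs from compound 3 in one place: 1-(oxan-4-yl)ethyl in place of (oxolan-3-yl)methyl on an oxygen on an aromatic ring. Going by the values given here, no measured step changes only the ring group on this oxygen; a 1.8-fold higher number from compound 1 to compound 3 (0.26 log units; within the scatter) and a 2.3-fold higher number from compound 2 to compound 3 (0.36 log units; beyond the scatter) both alter the linking atom as well, and a 1.3-fold lower number from compound 1 to compound 2 (0.10 log units; within the scatter) swaps ring groups on a nitrogen without a step beyond the scatter. The comparable ring swap on oxygen is therefore expected to give little change, with a 1.1-fold lower number from compound 3 to compound 4 (0.04 log units; within the scatter) as the estimate. Compound 4 is estimated at 4 nM, expected between 1.5 nM and 12 nM.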

Compound 4, half-maximal inhibitory concentration: 9.2 nM
Compound 4: the middle estimate sits 2.3-fold (0.36 log units) below what was measured; the range from low to high includes it.
By their numbers in this assay, from the lowest: compounds 2, 1 and 3 (each within the scatter of the next, the first and the last beyond it); then compound 4.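

Going by these compounds alone, on this oxygen, the ring group does affect the result: 1-(oxan-4-yl)ethyl in place of (oxolan-3-yl)methyl gives a 2.1-fold higher number from compound 3 to compound 4 (0.32 log units; beyond the scatter) in this assay, the first step that changes only this group. Against the nitrogen-linked compounds, the gaps are wider, at a 4.8-fold higher number from compound 2 to compound 4 (0.69 log units; beyond the scatter) and a 3.8-fold higher number from compound 1 to compound 4 (0.58 log units; beyond the scatter), which makes compound 4 the weakest inhibitor of the four. No available evidence explains this loss. The change alters both the ring and the branching on the chain, so these effects remain unseparated. An (oxan-4-yl)methyl group on the same oxygen would tell them apart.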